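This account rests on a few compounds, and the source may have more. Where it says the series, first, only, none or still open, it means among the compounds named here.

Working notes on the series. For compound 1 `Cc1ccc2oc(C)c(C(=O)NCc3ccc(N4CCC(c5ccc(OC(F)(F)F)cc5)CC4)cc3)c2c1` the entry in a toxicity assay on Vero cells (Chlorocebus sabaeus) for cytotoxicity, read by CCK-8 assay, with a stated time of 72 h (on this read-out higher numbers stand for weaker inhibition and lower numbers for stronger inhibition), reads "not determined" (no result reported). For compound 2 `Cc1nn2ccc(=O)[nH]c2c1C(=O)NCc1ccc(N2CCC(c3ccc(OC(F)(F)F)cc3)CC2)cc1` the entry reads "not determined" (no result reported). Going by the values given here, compound 3 `Cc1cn2c(C(=O)NCc3ccc(N4CCC(c5ccc(OC(F)(F)F)cc5)CC4)cc3)c(C)nc2s1` gives > 100000 nM, which is a limit and not a number, and it is the only reading so far in this assay.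

Compound 4 `Cc1cn2nc(C)c(C(=O)NCc3ccc(N4CCC(c5ccc(OC(F)(F)F)cc5)CC4)cc3)c2s1` has the same atoms as compound 3, joined differently: a group of 10 heavy atoms (7 carbon, 2 nitrogen, 1 sulfur; 2 five-membered aromatic rings with 2 hetero atoms each) in place of a group of 10 heavy atoms (7 carbon, 2 nitrogen, 1 sulfur; 2 five-membered aromatic rings with 2 hetero atoms each), on a carbonyl carbon, on a carbonyl carbon whose other neighbour is an amide-type nitrogen.

Among the compounds with values here, no measured step exists to scale this change, so the expected a number no higher from compound 3 to compound 4 (the limit leaves the size open) is none beyond the scatter, in neither direction. This expectation rests only on the limit of compound 3 at > 100000 nM. For compound 4 the estimated value is 100000 nM, with an expected range of 40000 nM to 200000 nM.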

Compound 4, half-maximal inhibitory concentration: > 100000 nM
Compound 4 gave a limit, no number (the forecaster's own chance of this, stated with the estimate: 75%); the middle value sits exactly at the limit.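

No step can be read between compound 3 and compound 4, as each entry is a limit and not a number. Still open, from the compounds shown here alone, is how far each compound lies past its limit, and whether exchanging one group for the other on the carbonyl carbon changes the reading at all.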